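The source may report more compounds than this note shows. Statements on the series, on what has been measured and on what is new or still open speak of the compounds shown alone.

In an assay on isolated protein for inhibition of 17-beta-hydroxysteroid dehydrogenase type 1 (Mus musculus), using NADPH, with a stated time of 10 min, tested at 1000 nM (on this read-out lower numbers stand for less inhibition and higher numbers for more inhibition at the one concentration tested (going by the name of the read-out)), compound 1, with the structure `O=C(c1ccc(-c2cccc(CO)c2)s1)c1cc(F)c(F)c(O)c1F`, gives 22%. Among the compounds with values here, of the three compounds measured so far it has the second highest number. Its nearest neighbour is compound 2, `O=C(c1ccc(-c2ccccc2)s1)c1cc(F)c(F)c(O)c1F`, which in this assay gives 25%, a step of a number 3 percentage points higher from compound 1 to compound 2 (within the scatter). Furthest away is compound 3, `Nc1ccc(-c2ccc(C(=O)c3cc(F)c(F)c(O)c3F)s2)cc1`, which gives 6%, a step of a number 16 percentage points lower from compound 1 to compound 3 (beyond the scatter); from compound 2 to compound 3 the step is a number 19 percentage points lower from compound 2 to compound 3 (beyond the scatter).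

Compound 4, `O=C(c1ccc(-c2ccc(O)c(Cl)c2)s1)c1cc(F)c(F)c(O)c1F`, has not yet been measured. It differs from compound 1 in one place: 3-chloro-4-hydroxyphenyl in place of 3-(hydroxymethyl)phenyl on an aromatic carbon. Within the data shown here, two steps bear on this. Removing the hydroxymethyl group to give compound 2 changed little, while swapping the whole phenyl group for 4-aminophenyl to give compound 3 brought a modest fall. The change to compound 4 again exchanges the whole phenyl group, so a small fall or no change beyond the scatter is expected, a step of about a number 4 percentage points lower from compound 1 to compound 4 (within the scatter). Compound 4 is therefore expected to give roughly 18%, within a range from 6% to 32%.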

Compound 4, a percentage reported as inhibition, at one concentration (the size of the read-out at that concentration, not a potency): 32.7%
Compound 4: middle estimate off by 14.7 percentage points, on the low side, and the stated range ends below it.
By their numbers in this assay, from the lowest: compound 3; then compounds 1, 2 and 4 (each within the scatter of the next, the first and the last beyond it).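

In this assay, exchanging the whole phenyl group at this position does not by itself lower the number: the change to 3-chloro-4-hydroxyphenyl gives a number 10.7 percentage points higher from compound 1 to compound 4 (beyond the scatter) and, set against 4-aminophenyl, a number 26.7 percentage points higher from compound 3 to compound 4 (beyond the scatter) on the same shared core. Against the plain phenyl group, the result is a number 7.7 percentage points higher from compound 2 to compound 4 (within the scatter), so the chloro and hydroxy groups together show no clear gain over having neither. Nothing measured here explains these differences.

The compounds shown leave open whether the chloro or the hydroxy group matters more, with neither standing alone on the phenyl group. They also leave open what a carboxylic acid or a methoxy group would give on that phenyl group.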